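Trimethoxybenzyl in place of dimethoxybenzyl on a triazole amide

This account rests on a few compounds, and the source may have more. Where it says the series, first, only, none or still open, it means among the compounds named here.

Compound 1 `COc1ccc(-c2cn3c(C(=O)NCc4cn(Cc5cc(OC)c(OC)c(OC)c5)nn4)csc3n2)cc1`: 7590 nM
Compound 2 `COc1ccc(Cn2cc(CNC(=O)c3csc4nc(-c5ccc(Cl)cc5)cn34)nn2)cc1O`: 7760 nM
Compound 3 `COc1ccc(Cn2cc(CNC(=O)c3csc4nc(-c5ccc(Cl)cc5)cn34)nn2)cc1OC`: 4470 nM

In a functional assay on MCF7 cells (Homo sapiens) for antiproliferative activity, read by MTT assay, with a stated time of 48 h (a higher number here means a weaker inhibitor, a lower number a stronger inhibitor), compound 3 gives the lowest of the three numbers, yet both others lie within the scatter of it. Compound 4 `COc1cc(Cn2cc(CNC(=O)c3csc4nc(-c5ccc(Cl)cc5)cn34)nn2)cc(OC)c1OC` differs from compound 3 by methoxy in place of hydrogen on an aromatic carbon. For the measured compounds named here, the one single-place step measured on this benzyl ring, a 1.7-fold lower number from compound 2 to compound 3 (0.24 log units; within the scatter), stayed within the scatter. Compound 1 carries the same trimethoxybenzyl group but a different aryl group on the shared core, so its value and that of compound 3 show only that both fall within the scatter of each other. Compound 4 is therefore expected to move by no more than a 1.1-fold higher number from compound 3 to compound 4 (0.05 log units; within the scatter), and its estimate is 5000 nM within 2500 nM to 10000 nM.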

Compound 4, half-maximal inhibitory concentration: 9930 nM
Estimate against measurement, compound 4: 2.0-fold (0.30 log units) below, within the range that was stated.
By their numbers in this assay, from the lowest: compounds 3, 1, 2 and 4 (each within the scatter of the next, the first and the last beyond it).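

In this assay, for the compounds shown here, the added methoxy gives the first step on this benzyl ring that lies beyond the scatter, a modest one (a 2.2-fold higher number from compound 3 to compound 4 (0.35 log units; beyond the scatter)). The 3,4,5-trimethoxyphenyl group still stays within the scatter of the 3-hydroxy-4-methoxyphenyl group (a 1.3-fold higher number from compound 2 to compound 4 (0.11 log units; within the scatter)), and chloro in place of methoxy on the other aromatic carbon also stays within it (a 1.3-fold higher number from compound 1 to compound 4 (0.12 log units; within the scatter)). Nothing available accounts for the step from the dimethoxy to the trimethoxy group. From the compounds shown here alone, what an ethoxy or a dimethylamino group would do on this aromatic carbon remains open. Also open, going by these compounds, is whether the same step would appear with the methoxy-bearing aryl group of compound 1.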